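A fluorinated chain replaces isopropyl on compound 1

This account rests on a few compounds, and the source may have more. Where it says the series, first, only, none or still open, it means among the compounds named here.

compound 1 `CC(C)c1ccc(NC(=O)c2csc(Cc3c(Cl)cccc3Cl)n2)cc1` 370 nM
compound 2 `O=C(Nc1ccc(Br)cc1)c1csc(Cc2c(Cl)cccc2Cl)n1` 400 nM

Of the compounds shown here, two have been measured in an assay on CHO cells, read by calcium flux; a lower number here means a stronger inhibitor, a higher number a weaker inhibitor. Compound 1 `CC(C)c1ccc(NC(=O)c2csc(Cc3c(Cl)cccc3Cl)n2)cc1` gives 370 nM, and compound 2 `O=C(Nc1ccc(Br)cc1)c1csc(Cc2c(Cl)cccc2Cl)n1` gives 400 nM. Compound 1 has the lowest of the two numbers, but its nearest neighbour is compound 2, and the step of a 1.1-fold higher number from compound 1 to compound 2 (0.03 log units; within the scatter) lies within the scatter, so the two cannot be ordered. Compound 3 `O=C(Nc1ccc(C(F)(F)C(F)(F)F)cc1)c1csc(Cc2c(Cl)cccc2Cl)n1` has not been measured yet. It differs from compound 1 in one place: 1,1,2,2,2-pentafluoroethyl in place of isopropyl on an aromatic carbon. Among the compounds with values here, the only measured step bearing on this change is a 1.1-fold higher number from compound 1 to compound 2 (0.03 log units; within the scatter), which replaced the same isopropyl with another group without moving the number beyond the scatter. Because the step of a 1.1-fold higher number from compound 1 to compound 2 (0.03 log units; within the scatter) stayed within the scatter, compound 3 is expected to move little, by a 1.1-fold higher number from compound 1 to compound 3 (0.03 log units; within the scatter). The estimate for compound 3 in this assay is 400 nM, with a range from 150 nM to 1100 nM.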

Compound 3, half-maximal inhibitory concentration: 290 nM
For compound 3 the middle estimate is 1.4-fold (0.14 log units) above the measured one; measured number inside the range.
By their numbers in this assay, from the lowest: compounds 3, 1 and 2 (each within the scatter of the next).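

In this assay, the position on the aromatic carbon para to a large group now takes 1,1,2,2,2-pentafluoroethyl, with 7 heavy atoms, in place of isopropyl, with 3, and the result is a 1.3-fold lower number from compound 1 to compound 3 (0.11 log units; within the scatter). Set against bromo, the same group gives a 1.4-fold lower number from compound 2 to compound 3 (0.14 log units; within the scatter), so isopropyl, bromo and 1,1,2,2,2-pentafluoroethyl cannot be ordered at this position, and the larger group shows that heavy-atom count alone does not move the number beyond the scatter in these compounds. Nothing available explains why these three groups read alike.

Going by these compounds, neither isopropyl nor 1,1,2,2,2-pentafluoroethyl carries a hydrogen-bond donor, an acceptor or a net charge, so it remains open how an amine or a carboxylic acid would read at this position. Also open, on these data alone, is whether a longer fluorinated chain would stay within the scatter on the shared core.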